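The source may hold more compounds than are shown below. What is called first, only, known or untested is meant among the compounds shown, and "the series" means these compounds.

Working notes on a series of sulfonylcarbamate biaryls read in an assay on membranes from HEK293 cells for displacement of a labelled ligand from Type-2 angiotensin II receptor (Homo sapiens), read by radioligand binding; on this read-out lower numbers stand for stronger inhibition and higher numbers for weaker inhibition. Compound 1 `CCCCOC(=O)NS(=O)(=O)c1ccc(CCC)cc1-c1ccc(Cn2c(C3CCCCC3)nc3ccccc32)cc1` gives 130 nM in this assay, the highest of the three numbers in hand. Compound 2 `CCCc1ccc(S(=O)(=O)NC(=O)OCCCC(F)(F)F)c(-c2ccc(Cn3c(C(C)(C)C)nc4ccccc43)cc2)c1` gives 4.5 nM in this assay and is the furthest from compound 1, while compound 3 `CCCCOC(=O)NS(=O)(=O)c1ccc(CCC)cc1-c1cc(F)c(Cn2c(C(C)(C)C)nc3ccccc32)c(F)c1` gives 11 nM in this assay and is the nearest to compound 1; both gaps lie beyond the scatter. Among the compounds with values here, compound 2 and compound 3 each differ from compound 1 in more than one place, so no single step between measured compounds can be drawn from these three.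

The next compound, compound 4 `CCCCOC(=O)NS(=O)(=O)c1ccc(CCC)cc1-c1ccc(Cn2c(CC(C)C)nc3ccccc32)cc1`, differs from compound 1 in one place: isobutyl in place of cyclohexyl on an aromatic carbon. Both measured compounds with lower numbers than compound 1 carry a different group at that same aromatic carbon, but each also carries other changes, so the comparison is loose. A moderate step down is expected, estimated as a 2.6-fold lower number from compound 1 to compound 4 (0.41 log units; beyond the scatter), though a result within the scatter cannot be ruled out. For compound 4 in this assay the estimate is 50 nM, with a range of 15 nM to 200 nM.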

Compound 4, inhibition constant: 19 nM
Beside the measured number, compound 4's estimate is 2.6-fold (0.42 log units) above it; low and high end bracket the measured number.
By their numbers in this assay, from the lowest: compound 2; then compounds 3 and 4 (each within the scatter of the next); then compound 1.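

In this assay, within the data shown here, replacing cyclohexyl with isobutyl on the aromatic carbon between two ring nitrogen atoms gives a 6.8-fold lower number from compound 1 to compound 4 (0.84 log units; beyond the scatter), the first change at this position that can be read on its own, as the earlier compounds differed from compound 1 in more than one place. Cyclohexyl has 6 heavy atoms and one six-membered non-aromatic ring, whereas isobutyl has 4 heavy atoms and no ring, so a ring at this position is not needed for compound 4 to reach 19 nM, although this single step cannot separate the loss of the ring from the loss of heavy atoms. Nothing available on the series accounts for the size of this step.

As far as these compounds go, it remains open whether cyclobutyl, which keeps a ring, or a hexyl chain, which keeps the carbon count of cyclohexyl without a ring, would read closer to isobutyl or to cyclohexyl at this carbon. The compounds shown also leave open how a group containing nitrogen, such as dimethylamino, would read at this position.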